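The source may report more compounds than this note shows. Statements on the series, on what has been measured and on what is new or still open speak of the compounds shown alone.

Measured in a functional assay on A2780 cells (Homo sapiens) for cytotoxicity, read by MTT assay, with a stated time of 72 h; a lower number here means a stronger inhibitor, a higher number a weaker inhibitor:
- Compound 1 `Cc1cc(C)cc(C(=O)N(CCCCCC(=O)Nc2ccccc2N)CC(=O)NC2CCCCC2)c1`: 42000 nM
- Compound 2 `Nc1ccccc1NC(=O)CCCCCN(CC(=O)NCc1ccccc1)C(=O)c1cccc2ccccc12`: 22800 nM

Only these two compounds have been measured so far. Compound 2, at 22800 nM, lies within the usual scatter of compound 1, so this assay does not separate them. The next compound, compound 3 `Nc1ccccc1NC(=O)CCCCCN(CC(=O)NC1CCCCC1)C(=O)c1cccc2ccccc12`, has cyclohexyl in place of benzyl on an amide-type nitrogen. Among the compounds with values here, no measured pair shows this exchange on its own, so the data give no direct size for it. The expectation therefore rests on the narrow spread so far, with compound 1 at 42000 nM and compound 2 at 22800 nM. No step beyond the scatter is expected, and a weak value in the same range seems most likely. The expected step is small: a 1.2-fold higher number from compound 2 to compound 3 (0.09 log units; within the scatter). Compound 3 is estimated at 28000 nM, with an expected range of 12000 nM to 60000 nM.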

Compound 3, half-maximal inhibitory concentration: 18100 nM
Beside the measured number, compound 3's estimate is 1.5-fold (0.19 log units) above it; measured number inside the range.
By their numbers in this assay, from the lowest: compounds 3, 2 and 1 (each within the scatter of the next, the first and the last beyond it).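

In this assay, cyclohexyl in place of benzyl on an amide-type nitrogen gives a 1.3-fold lower number from compound 2 to compound 3 (0.10 log units; within the scatter). Replacing the aromatic ring of benzyl with the non-aromatic ring of cyclohexyl therefore makes no clear difference at this position. Within the data shown here, with cyclohexyl on that nitrogen in both compounds, naphthalen-1-yl in place of 3,5-dimethylphenyl on a carbonyl carbon gives a 2.3-fold lower number from compound 1 to compound 3 (0.37 log units; beyond the scatter), the first single change here to exceed the scatter, though only modestly, and no measurement available here accounts for either step.

On these data alone, it remains open whether an open-chain group such as tert-butyl, or a ring carrying a carboxylic acid, would be tolerated as well as benzyl and cyclohexyl on that nitrogen. It is also unknown whether the naphthalen-1-yl step would hold with benzyl in place of cyclohexyl, or with a longer chain in the shared core.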